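The compounds below may be only part of what the source reports. "The series", "measured", "known", "first", "only" and "open" are said of these compounds alone.

Compound 1 `COc1ccccc1NC(=O)C1NCCc2ccccc21` carries a methoxy group on its six-membered aromatic ring of carbon only and a free amine nitrogen in its saturated ring. In a functional assay on NUGC-3 cells (Homo sapiens) for inhibition, read by sulforhodamine B assay, with a stated time of 48 h (on this read-out lower numbers stand for stronger inhibition of growth and higher numbers for weaker inhibition of growth), compound 1 gives > 10000 nM, which is a limit of the assay rather than a number (the limit of > 10000 nM in this assay, at which 1 of the 2 values shown sits). Compound 2 `COc1ccccc1NC(=O)C1c2ccccc2CCN1C(=O)c1ccc(Cl)cc1` adds a (4-chlorophenyl)carbonyl to that amine nitrogen, and in this assay compound 2 gives 1590 nM. Among the compounds with values here, the single measured step, an at least 6.2-fold lower number from compound 1 to compound 2 (0.79 log units; beyond the scatter), therefore concerns the ring nitrogen and leaves the aromatic substituent untouched.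

Compound 3 `O=C(Nc1ccccc1C(F)(F)F)C1NCCc2ccccc21` is changed at a different place: trifluoromethyl in place of methoxy on an aromatic carbon. Its ring amine stays unacylated, as in compound 1. Within the data shown here, no measured step speaks to a change of the aromatic substituent, and the step from compound 1 to compound 2 offers no guide to it. Compound 1 stands at the limit, so a shift beyond the scatter in either direction cannot be read from what is known. Compound 3 is expected to remain at or near that limit, estimated at 15000 nM with a range from 3000 nM to 50000 nM. That estimate amounts to an expected step that the limit leaves unreadable from compound 1 to compound 3.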

Compound 3, concentration for 50% growth inhibition: > 10000 nM
Compound 3 ended at the assay's limit (the forecaster's own chance of this, stated with the estimate: 70%); the middle value lies beyond the limit too.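

Within the data shown here, compound 3, like compound 1, sits at a limit of this assay rather than at a number, so no step between compound 1 and compound 3 can be read: the limit of > 10000 nM in this assay, at which 2 of the 3 values shown sit. The compounds shown leave open whether trifluoromethyl and methoxy differ at all in growth inhibition when the ring nitrogen carries a (4-chlorophenyl)carbonyl.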